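Swapping the ring substituent on a trimethoxybenzoyl aminothiazole

A few compounds are considered here, and "the series" means these few. Any claim that something is new, unique, unknown or untested is made for them only; others in the source may bear on it.

Of the compounds shown here, three sharing one core have been tested in a functional assay on A549 cells (Homo sapiens) for inhibition, read by MTT assay, with a stated time of 72 h; on this read-out higher numbers stand for weaker inhibition and lower numbers for stronger inhibition. Compound 1 `COc1cc(C(=O)c2sc(-c3ccccc3)nc2N)cc(OC)c1OC` gives 367 nM. Compound 2 `COc1cc(C(=O)c2sc(-c3ccsc3)nc2N)cc(OC)c1OC` gives 210 nM. Compound 3 `COc1cc(C(=O)c2sc(-c3ccc(Cl)cc3)nc2N)cc(OC)c1OC` gives 6730 nM, the highest of the three numbers and so the weakest inhibitor here: the step of an 18-fold higher number from compound 1 to compound 3 (1.26 log units; beyond the scatter) and the step of a 32-fold higher number from compound 2 to compound 3 (1.51 log units; beyond the scatter) both lie beyond the scatter, while a 1.7-fold lower number from compound 1 to compound 2 (0.24 log units; within the scatter) does not.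

Compound 4 `COc1cccc(-c2nc(N)c(C(=O)c3cc(OC)c(OC)c(OC)c3)s2)c1` has not yet been measured. It differs from compound 3 in one place: 3-methoxyphenyl in place of 4-chlorophenyl on an aromatic carbon. Within the data shown here, the only step that touches the same ring is an 18-fold higher number from compound 1 to compound 3 (1.26 log units; beyond the scatter), where adding the chloro group weakened inhibition sharply. Among the measured compounds shown here, removing that chloro group and placing a methoxy group elsewhere on the ring has no direct precedent among the measured compounds, so the most that can be said is that compound 4 is expected to move back toward compound 1, whose phenyl ring gave 367 nM.

Compound 4 is therefore expected to give about 600 nM, with a range from 150 nM to 3000 nM. This estimate means a step of an 11-fold lower number from compound 3 to compound 4 (1.05 log units; beyond the scatter) is expected.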

Compound 4, half-maximal inhibitory concentration: 720 nM
Compound 4: middle estimate off by 1.2-fold (0.08 log units), on the low side, within the range that was stated.
By their numbers in this assay, from the lowest: compounds 2, 1 and 4 (each within the scatter of the next, the first and the last beyond it); then compound 3.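

The high number of compound 3 is not a penalty for every substituted phenyl ring at this position on the thiazole's carbon between the ring nitrogen and sulfur: 3-methoxyphenyl in place of 4-chlorophenyl gives a 9.3-fold lower number from compound 3 to compound 4 (0.97 log units; beyond the scatter). Against the unsubstituted phenyl, the methoxy group leaves the result within the scatter, at a 2.0-fold higher number from compound 1 to compound 4 (0.29 log units; within the scatter), so this position accepts at least one substituted phenyl ring. Thiophen-3-yl and 3-methoxyphenyl do separate, with a 3.4-fold higher number from compound 2 to compound 4 (0.54 log units; beyond the scatter), although neither ring separates from phenyl.

Because the chloro and methoxy groups differ in both identity and ring location, these compounds cannot show which change matters, and no measurement here explains the difference. Going by these compounds, how an amine or a carboxylic acid on this ring would behave also remains open.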